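This account rests on a few compounds, and the source may have more. Where it says the series, first, only, none or still open, it means among the compounds named here.

Working notes on the series.

Compound 1 `COc1cc(-c2cc(/C=C/C(=O)c3ccc(N)cc3)[nH]n2)cc(OC)c1OC` gives -18% in a functional assay on SR cells (Homo sapiens) for cytotoxicity, read by sulforhodamine B assay, with a stated time of 48 h, tested at 10 uM; on this read-out higher numbers stand for a weaker effect at the one concentration tested and lower numbers for a stronger effect. Compound 2 `COc1ccc(-c2cc(/C=C/C(=O)c3ccc(N)cc3)[nH]n2)cc1OC` gives -13% in this assay. The step between them, (hydrogen in place of methoxy on an aromatic carbon), gives a number 5 percentage points higher from compound 1 to compound 2 (within the scatter). Compound 3 `COc1cc(C(=O)/C=C/c2cc(-c3cc(OC)c(OC)c(OC)c3)n[nH]2)cc(OC)c1OC` gives 12% in this assay; the difference between the core of compound 3 and the core of compound 1 is not broken down here. Compound 4 `COc1ccc(-c2cc(/C=C/C(=O)c3cc(OC)c(OC)c(OC)c3)[nH]n2)cc1OC` has not yet been measured in this assay. It differs from compound 3 by hydrogen in place of methoxy on an aromatic carbon, the same change as from compound 1 to compound 2. Because that earlier step gave a number 5 percentage points higher from compound 1 to compound 2 (within the scatter), a step of similar size is expected here, so compound 4 is estimated to move by a number 3 percentage points higher from compound 3 to compound 4 (within the scatter). The expected value for compound 4 in this assay is 15%, between 0% and 30%.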

Compound 4, a percentage reported as activity, at one concentration (the size of the read-out at that concentration, not a potency): -10%
Compound 4: middle estimate off by 25 percentage points, on the high side, and the stated range ends above it.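

In this assay, hydrogen in place of methoxy on an aromatic carbon gives a number 22 percentage points lower from compound 3 to compound 4 (beyond the scatter), a stronger effect on this read-out. The change does not carry over as one fixed step from core to core: the same change on two cores in this assay, a number 5 percentage points higher (within the scatter) from compound 1 to compound 2 and a number 22 percentage points lower (beyond the scatter) from compound 3 to compound 4, 27 percentage points apart, beyond the scatter of two such steps So for these two pairs the outcome of the change differs with the core, but two pairs give no reason for the difference and no rule for any further core.

The compounds shown leave open how the same change behaves on a third core. They also leave open whether a chlorine atom or a carboxylic acid in place of that methoxy would follow either pair.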